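The source may hold more compounds than are shown below. What is called first, only, known or untested is meant among the compounds shown, and "the series" means these compounds.

In a functional assay on HCT-116 cells (Homo sapiens) for antiproliferative activity, read by CellTiter-Glo, with a stated time of 72 h (a lower number here means a stronger inhibitor, a higher number a weaker inhibitor), compound 1 (`O=C(NO)c1cccc(/C=C/c2ccnc(-c3ccccc3O)c2)c1`) gives 3360 nM. As far as these compounds go, compound 2 (`Cc1ccc(-c2cncc(/C=C/c3ccc(C(=O)NO)cc3)c2)cc1`) gives > 10000 nM, which is a limit of the assay and not a number, so its exact standing is unknown. Compound 3 (`O=C(NO)c1ccc(/C=C/c2cncc(-c3ccc(C(F)(F)F)cc3)c2)cc1`) differs from compound 2 in one place, with trifluoromethyl in place of methyl on an aromatic carbon, para to a large group: trifluoromethyl in place of methyl on an aromatic carbon. Within the data shown here, no measured pair tests this change, and no step beyond the scatter is expected in this assay, in either direction. The estimated step runs a number no higher from compound 2 to compound 3 (the limit leaves the size open). For compound 3, the expected value is 10000 nM, with an estimated range of 4000 nM to 20000 nM.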

Compound 3, half-maximal inhibitory concentration: > 10000 nM
Compound 3 gave a limit, no number (the forecaster's own chance of this, stated with the estimate: 65%); the middle value lies on the limit itself.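

Compound 2 and compound 3 both stop at a limit and not at a number, so no step can be read between them: the limit of > 10000 nM in this assay, at which 2 of the 3 values shown sit.

The compounds shown leave open whether trifluoromethyl in place of methyl changes antiproliferative activity at all.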